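Swapping a Chlorophenyl Ring for a Chloropyridine Ring

The source may hold more compounds than are shown below. What is called first, only, known or untested is meant among the compounds shown, and "the series" means these compounds.

Measured in an in vitro ADME assay on microsomes from liver (Homo sapiens) for metabolic stability, tested at 1 uM; a higher number here means faster removal of the compound, a lower number slower removal:
- Compound 1 `Cn1c(CN2C[C@@H]3C(COc4ccccc4)[C@@H]3C2)nc2ccccc21`: 14.2 mL/min/kg
- Compound 2 `Cn1c(CN2C[C@@H]3C(COc4cc(F)ccc4F)[C@@H]3C2)nc2ccccc21`: > 18.7 mL/min/kg (a limit, not a number)
- Compound 3 `Cn1c(CN2C[C@@H]3C(COc4ccc(Cl)cc4)[C@@H]3C2)nc2ccccc21`: 6.6 mL/min/kg

Compound 3 has the lower of the two actual numbers, while compound 2 has only a limit. The unmeasured compound 4 `Cn1c(CN2C[C@@H]3C(COc4ccc(Cl)cn4)[C@@H]3C2)nc2ccccc21` carries 5-chloropyridin-2-yl in place of 4-chlorophenyl on an oxygen on a saturated carbon.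

Two measured steps changed this same group: a 2.2-fold lower number from compound 1 to compound 3 (0.33 log units; beyond the scatter) and an at least 2.8-fold lower number from compound 2 to compound 3 (0.45 log units; beyond the scatter). Both were clear, so this group can move the number in this assay. Neither placed a hetero atom in the ring, so no step beyond the scatter is expected. The expected change is a 1.1-fold higher number from compound 3 to compound 4 (0.06 log units; within the scatter). Compound 4 is estimated at 7.5 mL/min/kg, within an expected range of 3.5 mL/min/kg to 15 mL/min/kg.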

Compound 4, clearance: 12.3 mL/min/kg
Beside the measured number, compound 4's estimate is 1.6-fold (0.21 log units) below it; measured number inside the range.
By their numbers in this assay, from the lowest: compounds 3, 4 and 1 (each within the scatter of the next, the first and the last beyond it). At a limit, above all of these: compound 2.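

In this assay, placing 5-chloropyridin-2-yl in place of 4-chlorophenyl gives a 1.9-fold higher number from compound 3 to compound 4 (0.27 log units; within the scatter), while the comparison with the unsubstituted phenyl gives a 1.2-fold lower number from compound 1 to compound 4 (0.06 log units; within the scatter). Compound 4 therefore cannot be separated from either compound 1 or compound 3, even though those two differ beyond the scatter, so the data cannot say whether the ring nitrogen cancels the change seen with chloro. Compound 2 has a limit and not a number: the limit of > 18.7 mL/min/kg in this assay, at which 1 of the 4 values shown sits. Placing 5-chloropyridin-2-yl in place of 2,5-difluorophenyl gives an at least 1.5-fold lower number from compound 2 to compound 4 (0.18 log units; that floor lies within the scatter), so this step shows only a floor.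

As far as these compounds go, whether a nitrile or a methoxy group in place of the chloro on the pyridine ring would move the number remains open.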